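Methoxy on the indole side of compound 2

The source may hold more compounds than are shown below. What is called first, only, known or untested is meant among the compounds shown, and "the series" means these compounds.

Within the data shown here, in a functional assay on DU-145 cells (Homo sapiens) for inhibition, read by trypan blue exclusion, with a stated time of 96 h (on this read-out higher numbers stand for weaker inhibition of growth and lower numbers for stronger inhibition of growth), compound 1 (`Cc1ccc(S/C(=C/c2c[nH]c3ccccc23)C(=O)c2ccc(Br)cc2)cc1`) gives 10000 nM and compound 2 (`O=C(/C(=C\c1c[nH]c2ccccc12)Sc1ccc(Br)cc1)c1ccc(Br)cc1`) gives 1000 nM as the lower of the two numbers so far. Compound 3 (`COc1ccc2[nH]cc(/C=C(/Sc3ccc(Br)cc3)C(=O)c3ccc(Br)cc3)c2c1`) differs from compound 2 by a single change (methoxy in place of hydrogen on an aromatic carbon): methoxy in place of hydrogen on an aromatic carbon of the six-membered aromatic ring of carbon only, part of a fused or bridged system of two rings. Among the measured compounds shown here, the one measured step (a 10-fold lower number from compound 1 to compound 2 (1.00 log units; beyond the scatter)) was bromo in place of methyl elsewhere in the structure. It shows that one substituent can move the number in this assay beyond the scatter, but it gives no direction for methoxy. The expected step is therefore small and stays within the scatter (a 1.3-fold lower number from compound 2 to compound 3 (0.10 log units; within the scatter)). For compound 3 the estimated value is 800 nM (expected range 200 nM to 3000 nM).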

Compound 3, concentration for 50% growth inhibition: 10000 nM
Beside the measured number, compound 3's estimate is 13-fold (1.10 log units) below it; the measured number lies above the stated range.
By their numbers in this assay, from the lowest: compound 2; then compounds 1 and 3 (each within the scatter of the next).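

In this assay, methoxy in place of hydrogen on an aromatic carbon of the six-membered aromatic ring of carbon only gives a 10-fold higher number from compound 2 to compound 3 (1.00 log units; beyond the scatter) and so weakens inhibition of growth beyond the scatter. Among these compounds, this is the first view of this position: it is not indifferent to substitution, and a group of only two heavy atoms is enough to move the number as far as the earlier change of bromo in place of methyl did elsewhere in the structure. Nothing available accounts for this loss, so it stands as an observation without an explanation.

As far as these compounds go, it remains open whether a hydroxyl, a fluoro group or an amine on this carbon would move the number the same way. From the compounds shown here alone, it also remains open whether methoxy on another carbon of this ring would give a similar step.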